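The source may report more compounds than this note shows. Statements on the series, on what has been measured and on what is new or still open speak of the compounds shown alone.

In an assay on a protein complex for binding affinity to Neuronal acetylcholine receptor; alpha3/beta4 (Rattus norvegicus) (on this read-out higher numbers stand for weaker inhibition and lower numbers for stronger inhibition), compound 2 `CN1CCC[C@H]1COc1cncc(C#CCO)c1` gives 23000 nM, and compound 1 `CCCCC#Cc1cncc(OC[C@@H]2CCCN2C)c1` gives 40000 nM; the step of a 1.7-fold lower number from compound 1 to compound 2 (0.24 log units; within the scatter) stays within the scatter, so the two values cannot be ranked. Compound 3 `C#Cc1cncc(OC[C@@H]2CCCN2C)c1` is not yet measured; it differs from compound 2 by hydrogen in place of hydroxymethyl on a triple-bonded carbon. Within the data shown here, the only measured step that bears on this, from compound 1 to compound 2, exchanged a propyl for a hydroxy group at the end of the triple bond and moved nothing beyond the scatter, so no step beyond the scatter is expected here either. Compound 3 is expected near 30000 nM (range 10000 nM to 90000 nM), an expected step of a 1.3-fold higher number from compound 2 to compound 3 (0.12 log units; within the scatter).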

Compound 3, inhibition constant: 6800 nM
Compound 3: the middle estimate sits 4.4-fold (0.64 log units) above what was measured; measured number outside the range, below it.
By their numbers in this assay, from the lowest: compound 3; then compounds 2 and 1 (each within the scatter of the next).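

In this assay the substituent on the triple-bonded carbon does matter: hydrogen gives a 3.4-fold lower number from compound 2 to compound 3 (0.53 log units; beyond the scatter) in place of hydroxymethyl and a 5.9-fold lower number from compound 1 to compound 3 (0.77 log units; beyond the scatter) in place of butyl. Among these compounds, the earlier pair showed only that two chain-bearing compounds could not be ranked, whereas here removing the chain altogether separates compound 3 from both. No measured evidence bears on why this happens. Still open, as far as these compounds go, is whether a methyl on the triple-bonded carbon would keep the number of compound 3, and whether an amine at the chain end would behave like the hydroxymethyl of compound 2.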